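A few compounds are considered here, and "the series" means these few. Any claim that something is new, unique, unknown or untested is made for them only; others in the source may bear on it.

Measured compounds in a functional assay on PC-3 cells (Homo sapiens) for inhibition, read by MTT assay, with a stated time of 48 h; a higher number here means a weaker inhibitor, a lower number a stronger inhibitor:
- compound 1 `COc1cc(Cn2cc(COc3cccc(/C=C4\C(=O)Nc5ccccc54)c3)nn2)cc(OC)c1`: 31700 nM
- compound 2 `O=C1Nc2ccc(Cl)cc2/C1=C/c1cccc(OCc2cn(Cc3ccccc3)nn2)c1`: a limit of the assay, > 50000 nM
- compound 3 `O=C1Nc2ccc([N+](=O)[O-])cc2/C1=C\c1cccc(OCc2cn(Cc3ccccc3)nn2)c1`: a limit of the assay, > 50000 nM

Compound 2 stands at the limit of this assay. Its value > 50000 nM is a limit and not a number, so its place among the series can only be read from that. Compound 3 also returns a limit in this assay, > 50000 nM. Among the measured compounds shown here, compound 1 is the only member with a measured number, 31700 nM, and so the only fixed point for the series.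

the limit of > 50000 nM in this assay, at which 2 of the 3 values shown sit, is the mark against which any new member will be judged.

Compound 4 `CC(=O)c1ccc2c(c1)/C(=C/c1cccc(OCc3cn(Cc4ccccc4)nn3)c1)C(=O)N2` is not yet measured. It differs from compound 2 by acetyl in place of chloro on an aromatic carbon, in words: acetyl in place of chloro on an aromatic carbon. For the measured compounds named here, no step between two measured compounds is given that would show how such a change reads in this assay. With compound 2 at a limit and compound 1 barely below it, the expected step from compound 2 to compound 4 is a number no higher from compound 2 to compound 4 (the limit leaves the size open), which is no change beyond the scatter. Compound 4 is therefore expected to give about 50000 nM in this assay, within 20000 nM to 120000 nM, and a limit rather than a number is the more likely outcome.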

Compound 4, half-maximal inhibitory concentration: > 50000 nM
Compound 4: no number, only a limit; the forecaster's own chance of this, stated with the estimate: 60%; the middle value sits exactly at the limit.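

In this assay, compound 2 and compound 4 both return only a limit of the assay, so no step can be read between them. The compounds shown leave open how acetyl in place of chloro on an aromatic carbon changes inhibition in this assay.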